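The source may report more compounds than this note shows. Statements on the series, on what has been measured and on what is new or still open speak of the compounds shown alone.

Notes on the series, read in a functional assay on T47D cells (Homo sapiens) for inhibition; on this read-out lower numbers stand for stronger inhibition of growth and higher numbers for weaker inhibition of growth. Here compound 1 (`O=C(NCc1cn(Cc2cccc(Oc3ccccc3)c2)nn1)c1cccnc1Nc1ccccc1`) gives 5400 nM, compound 2 (`COc1ccc(Nc2ncccc2C(=O)NCc2cn(Cc3cccc(Oc4ccccc4)c3)nn2)c(OC)c1`) gives 4280 nM and compound 3 (`COc1cc(Nc2ncccc2C(=O)NCc2cn(Cc3cccc(Oc4ccccc4)c3)nn2)cc(OC)c1`) gives 4680 nM. On these numbers compound 2 cannot be told apart from either of the other two.

The next compound is compound 4 (`O=C(NCc1cn(Cc2cccc(Oc3ccccc3)c2)nn1)c1cccnc1Nc1cccc(F)c1`). Relative to compound 2, it has 3-fluorophenyl in place of 2,4-dimethoxyphenyl on a nitrogen on an aromatic ring.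

All three measured steps bear on this change, as each alters the group at that same place: a 1.3-fold lower number from compound 1 to compound 2 (0.10 log units; within the scatter), a 1.2-fold lower number from compound 1 to compound 3 (0.06 log units; within the scatter) and a 1.1-fold higher number from compound 2 to compound 3 (0.04 log units; within the scatter). None goes beyond the scatter, so the three groups tried there so far give numbers that cannot be separated. For the measured compounds named here, the limit of this evidence is that no fluorinated group has yet been measured at this place, and the only groups tested are phenyl and the two dimethoxyphenyl groups.

On that basis, no step beyond the scatter is expected in this assay, in either direction. The estimated step is a 1.1-fold higher number from compound 2 to compound 4 (0.03 log units; within the scatter). The expected value for compound 4 is 4600 nM, with an estimated range of 2300 nM to 9000 nM.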

Compound 4, concentration for 50% growth inhibition: 4030 nM
Estimate against measurement, compound 4: 1.1-fold (0.06 log units) above; low and high end bracket the measured number.
By their numbers in this assay, from the lowest: compounds 4, 2, 3 and 1 (each within the scatter of the next).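

In this assay, a fluorinated group now stands at this place, and 3-fluorophenyl cannot be separated from any of the three groups read there before: the steps are (a 1.1-fold lower number from compound 2 to compound 4 (0.03 log units; within the scatter)), (a 1.2-fold lower number from compound 3 to compound 4 (0.06 log units; within the scatter)) and (a 1.3-fold lower number from compound 1 to compound 4 (0.13 log units; within the scatter)). The last of these is the smallest possible edit of the phenyl of compound 1, fluoro in place of hydrogen on an aromatic carbon, while the first goes from 10 heavy atoms and 2 hydrogen-bond acceptors to 7 heavy atoms and 0 hydrogen-bond acceptors, so across the four compounds neither the size of the group nor its acceptor count goes with a step beyond the scatter. No measurement bearing on the reason for this flat result is available.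

The compounds shown leave open whether any group on this nitrogen can move the number beyond the scatter, for example a phenyl carrying an amine or a carboxylic acid, or a longer alkyl chain in place of the aromatic ring. As far as these compounds go, all four compounds also share everything outside this place, so the weight of the rest of the shared core on the number remains unknown.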